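A few compounds are considered here, and "the series" means these few. Any claim that something is new, unique, unknown or untested is made for them only; others in the source may bear on it.

Of the compounds shown here, three sharing one core have been tested so far, all carrying ester groups on their aromatic ring. In a functional assay on MCF7 cells (Homo sapiens) for antiproliferative activity, read by MTT assay, with a stated time of 72 h (a lower number here means a stronger inhibitor, a higher number a weaker inhibitor), compound 1 `COc1ccc(C(=O)Oc2ccc(C(=O)C3=C4OC(C)(C)[C@@H](CC=C(C)C)C[C@@]45C[C@@H](CC=C(C)C)C(C)(C)[C@H]4CCC(C)(C)O[C@]45OC3=O)cc2OC(=O)c2ccc(OC)cc2)cc1` gives > 20000 nM, which is a limit of the assay and not a number. Compound 3 `CC(C)=CC[C@H]1C[C@]23C[C@@H](CC=C(C)C)C(C)(C)[C@H]4CCC(C)(C)O[C@]42OC(=O)C(C(=O)c2ccc(OC(=O)c4ccccc4)c(OC(=O)c4ccccc4)c2)=C3OC1(C)C` gives > 20000 nM, again a limit. Compound 2 `CCCCCCCC(=O)Oc1cc(C(=O)C2=C3OC(C)(C)[C@@H](CC=C(C)C)C[C@@]34C[C@@H](CC=C(C)C)C(C)(C)[C@H]3CCC(C)(C)O[C@]34OC2=O)ccc1O` gives > 20000 nM, also a limit. Compound 2 therefore has no exact value, and it cannot be ranked against the other two, since the whole picture so far is the limit of > 20000 nM in this assay, at which 3 of the 3 values shown sit.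

Compound 4 `CC(C)=CC[C@H]1C[C@]23C[C@@H](CC=C(C)C)C(C)(C)[C@H]4CCC(C)(C)O[C@]42OC(=O)C(C(=O)c2ccc(O)c(O)c2)=C3OC1(C)C` is the next to be tested. It comes from compound 2 by one change: hydrogen in place of heptylcarbonyl on an oxygen on an aromatic ring. In words, hydrogen takes the place of heptylcarbonyl on an oxygen on an aromatic ring, so the (heptylcarbonyl)oxy group becomes hydroxy. Compound 4 thus carries none of the ester groups found in the three tested compounds.

Going by the values given here, no measured pair shows what this change does, so any expectation here is tentative. A modest move toward a lower number in this assay is expected, with an at least 2.2-fold lower number from compound 2 to compound 4 (0.34 log units; beyond the scatter) as the estimated step, and a result still at the limit would be no surprise. For compound 4 the estimated half-maximal inhibitory concentration is 9000 nM, with an expected range of 3000 nM to 25000 nM.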

Compound 4, half-maximal inhibitory concentration: 13500 nM
Estimate against measurement, compound 4: 1.5-fold (0.18 log units) below; low and high end bracket the measured number.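

Going by these compounds alone, replacing heptylcarbonyl with hydrogen on an oxygen on an aromatic ring, so that the (heptylcarbonyl)oxy group becomes hydroxy, gives the first exact value on this core in this assay, with compound 4 at 13500 nM. Compound 1, compound 2 and compound 3 remain at a limit of the assay: the limit of > 20000 nM in this assay, at which 3 of the 4 values shown sit. The result can be read only as a floor, an at least 1.4-fold lower number from compound 2 to compound 4 (0.17 log units; that floor lies within the scatter), so this pair alone does not establish a change larger than the usual scatter of repeated measurements, although the true step could be larger. What the limits alone could not show is that a compound on this core with hydroxy at this oxygen has a measurable half-maximal inhibitory concentration in this assay.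

The compounds shown leave open whether an acetyl group, with a much shorter chain than heptylcarbonyl, or a methyl group on this same oxygen would also give an exact value. They also leave open whether an amine in place of this hydroxy would give a lower or a higher number.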